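Moving a Fluorine Around a Phenyl Ring

A few compounds are considered here, and "the series" means these few. Any claim that something is new, unique, unknown or untested is made for them only; others in the source may bear on it.

Compound 1 `Cc1cc(C(=O)O)ccc1CN1CCC[C@H](O[C@H](CO)c2cc(Cl)cc(Cl)c2)[C@@H]1c1cccc(F)c1` is one of three compounds with numbers in an assay on isolated protein for activation of cGMP-dependent protein kinase 1 (Homo sapiens), read by ADP-Glo, with stated times of 30 min and 2 h, in the presence of a further agent that is not named here; on this read-out higher numbers stand for an effect only at larger amounts of compound and lower numbers for an effect already at smaller amounts. In this assay compound 1 gives 12000 nM, the second highest of the three numbers. The nearest is compound 3 `OC[C@@H](O[C@H]1CCCN(Cc2nc3ccccc3[nH]2)[C@H]1c1ccccc1)c1cc(Cl)cc(Cl)c1`, which in this assay gives 4700 nM, a lower number that lies beyond the usual scatter. The furthest is compound 2 `Cc1cc(C(=O)O)ccc1CN1CC[C@H](OC(CO)c2cc(Cl)cc(Cl)c2)[C@@H]1c1ccccc1`, which in this assay gives 133000 nM, a higher number that also lies well beyond the scatter. Neither of these two shares a single-point difference with compound 1, so they only frame where it sits.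

Compound 4 `Cc1cc(C(=O)O)ccc1CN1CCC[C@H](O[C@H](CO)c2cc(Cl)cc(Cl)c2)[C@@H]1c1ccccc1F` keeps the same atoms as compound 1, joined differently: 2-fluorophenyl in place of 3-fluorophenyl on a saturated ring carbon. Among the compounds with values here, no measured pair shows what this move does. The step from compound 1 to compound 4 is therefore expected to be small, in no fixed direction, and likely within the scatter of repeated measurements, as no change at the digits printed from compound 1 to compound 4 (within the scatter). For compound 4 the estimate in this assay is 12000 nM, with a range from 4000 nM to 40000 nM.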

Compound 4, half-maximal effective concentration: 2600 nM
Compound 4: the middle estimate sits 4.6-fold (0.66 log units) above what was measured, and the stated range ends above it.
By their numbers in this assay, from the lowest: compounds 4 and 3 (each within the scatter of the next); then compound 1; then compound 2.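

In this assay, 2-fluorophenyl in place of 3-fluorophenyl on this saturated ring carbon gives a 4.6-fold lower number from compound 1 to compound 4 (0.66 log units; beyond the scatter) while the atoms stay the same. Within the data shown here, this is the first single-point comparison in the set, and it shows that the location of the fluorine on this phenyl ring alone can move the number beyond the usual scatter. The data shown contain no measurement that accounts for this shift.

Still open, from the compounds shown here alone, is how a plain phenyl ring on the same core would compare with compound 4, and whether a chlorine atom or a methoxy group in place of the fluorine would give a similar result. It is also unknown whether the same fluorine move would give a step of similar size with a different group on the ring nitrogen.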